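The compounds below may be only part of what the source reports. "The series", "measured", "known", "first", "only" and "open" are said of these compounds alone.

Of the compounds shown here, three of this shared core have been measured in a functional assay on IMR-32 cells (Homo sapiens) for cytotoxicity, read by sulforhodamine B assay, with a stated time of 48 h; a higher number here means a weaker inhibitor, a lower number a stronger inhibitor. Compound 1 `CC(=O)N1N=C(c2cccc3ccccc23)CC1c1ccccc1[N+](=O)[O-]` gives 3980 nM in this assay. Compound 3 `COc1ccc(C2CC(c3ccc4ccccc4c3)=NN2CC=O)c(OC)c1OC` gives 780 nM. Compound 2 `O=CCN1N=C(c2ccc3ccccc3c2)CC1c1ccccc1` gives 10000 nM, the highest of the three numbers: the nearest is compound 1 and the furthest is compound 3, and both gaps lie beyond the scatter, so compound 2 is the weakest inhibitor of the set as measured.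

Compound 4 `O=CCN1N=C(c2ccc3ccccc3c2)CC1c1ccco1` has not yet been measured in this assay. It differs from compound 2 in one place: furan-2-yl in place of phenyl on a saturated ring carbon. For the measured compounds named here, no measured pair shows this change, so its effect can only be estimated. An aromatic five-membered ring with one oxygen replacing an aromatic six-membered ring of carbon is a modest change, and no step beyond the scatter is expected in either direction. The step from compound 2 to compound 4 is therefore estimated as a 1.1-fold lower number from compound 2 to compound 4 (0.05 log units; within the scatter). Compound 4 is expected to give about 9000 nM in this assay, within a range from 3000 nM to 25000 nM.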

Compound 4, half-maximal inhibitory concentration: 11000 nM
For compound 4 the middle estimate is 1.2-fold (0.09 log units) below the measured one, within the range that was stated.
By their numbers in this assay, from the lowest: compound 3; then compound 1; then compounds 2 and 4 (each within the scatter of the next).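

In this assay, for the compounds shown here, furan-2-yl in place of phenyl on the saturated ring carbon gives a 1.1-fold higher number from compound 2 to compound 4 (0.04 log units; within the scatter) and so provides the first step in the set between compounds that differ in one place. With the formylmethyl group kept, this position does not separate the five-membered aromatic ring with one oxygen from the six-membered aromatic ring of carbon, and the hydrogen-bond acceptor that furan-2-yl brings goes with no step beyond the scatter. Nothing at hand gives a cause for this result.

The compounds shown leave open whether thiophen-2-yl, pyridin-2-yl or a non-aromatic cyclohexyl group at this position would also stay within the scatter of phenyl. They also leave open whether the same exchange of phenyl for furan-2-yl would give a similar step with a different group on the ring nitrogen.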